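Propyl in place of oxan-4-yl on the ring amine

A few compounds are considered here, and "the series" means these few. Any claim that something is new, unique, unknown or untested is made for them only; others in the source may bear on it.

The series is followed in a functional assay (strain AB) with Danio rerio as the target, read by microscopy, with a stated time of 1 h; on this read-out lower numbers stand for an effect already at smaller amounts and higher numbers for an effect only at larger amounts of compound. Compound 1 `NC(=O)c1c(NC(=O)Nc2ccc(Cl)cc2)sc2c1CCN(C1CCOCC1)C2` gives 2830 nM in this assay. Of the two numbers shown it holds the higher one; the nearest is compound 2 `CC1(C)Cc2c(sc(NC(=O)Nc3ccc(Cl)cc3)c2C(N)=O)C(C)(C)N1`, which in this assay gives 1240 nM, a lower number that lies beyond the scatter. Compound 3 `CC1CCc2nc(NC(=O)Nc3ccc(Cl)cc3)sc2C1`, which lacks the carboxamide on the shared core, gives only > 25000 nM in this assay, a limit of the measurement and not a number; the evidence on this point is the limit of > 25000 nM in this assay, at which 1 of the 3 values shown sits.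

The next compound, compound 4 `CCCN1CCc2c(sc(NC(=O)Nc3ccc(Cl)cc3)c2C(N)=O)C1`, departs from compound 1 in one place: propyl in place of oxan-4-yl on an amine nitrogen in a ring. Among the compounds with values here, no measured pair in the set differs in just this way, so the size of the step has to be judged from the change alone. Compound 2 and compound 1 keep the carboxamide and the aryl urea and stay within a modest distance of one another, and compound 4 keeps both as well. The expected step from compound 1 to compound 4 is therefore a 1.1-fold lower number from compound 1 to compound 4 (0.05 log units; within the scatter), a small movement that may not exceed the scatter in either direction. Compound 4 is estimated at 2500 nM in this assay, with a range from 800 nM to 8000 nM.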

Compound 4, half-maximal effective concentration: 3500 nM
For compound 4 the middle estimate is 1.4-fold (0.15 log units) below the measured one, and the stated range covers the measured number.
By their numbers in this assay, from the lowest: compound 2; then compounds 1 and 4 (each within the scatter of the next). At a limit, above all of these: compound 3.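

Within the data shown here, on the amine nitrogen in a ring, putting propyl in place of oxan-4-yl gives a 1.2-fold higher number from compound 1 to compound 4 (0.09 log units; within the scatter) in this assay, so this pair offers the first single-place comparison and shows no separation between the two groups. In this one pair, the six-membered ring of oxan-4-yl and its hydrogen-bond acceptor can be exchanged for an open three-carbon chain without the read-out leaving the scatter, which says that the read-out does not depend on that ring or that acceptor here, though only for these two groups at this position. Nothing measured in the compounds shown bears on why this exchange leaves the read-out within the scatter.

Open, as far as these compounds go, is whether this tolerance extends to other groups on the same nitrogen, such as a longer chain, a benzyl group, an acetyl group or a chain ending in a carboxylic acid, and whether the nitrogen without any such group behaves the same way. Compound 2 differs from compound 1 in more than one place, so its lower number cannot yet be tied to any single change on the shared core.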